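A few compounds are considered here, and "the series" means these few. Any claim that something is new, unique, unknown or untested is made for them only; others in the source may bear on it.

Working notes on the series, following the step from compound 3 (`CCC/N=C1\S/C(=C\c2ccc(C(=O)O)cc2)C(=O)N1c1ccccc1O`) to compound 4 (`CCC/N=C1\S/C(=C\c2ccc(C(=O)OCC(O)CO)cc2)C(=O)N1c1ccccc1O`). In an ADME assay on a cell-free system (plasma, Homo sapiens) for metabolic stability, at 37 degrees C (on this read-out higher numbers stand for a longer-lived compound and lower numbers for a shorter-lived compound), compound 3 gives > 3 h as a limit and not a number. Compound 1 (`CCC/N=C1\S/C(=C\c2ccc(C(=O)OC)c(Cl)c2)C(=O)N1c1ccccc1C`) gives > 3 h as a limit as well. Compound 2 (`CCC/N=C1\S/C(=C\c2ccc(C(=O)OCCO)cc2)C(=O)N1c1ccccc1C`) likewise gives > 3 h as a limit. Compound 3 therefore stands with the others (the limit of > 3 h in this assay, at which 3 of the 3 values shown sit) and no order among the three can be read.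

Compound 4 carries 2,3-dihydroxypropyl in place of hydrogen on an oxygen next to a carbonyl group so that carboxy becomes (2,3-dihydroxypropoxy)carbonyl. For the measured compounds named here, no measured pair isolates this change. The nearest guide is compound 2, also an ester, with its limit of > 3 h in this assay as the only support for the expectation. The expected change is a step that the limit leaves unreadable from compound 3 to compound 4 and no shift beyond the scatter is estimated in either direction. For compound 4 the estimated half-life is 4 h with an expected range of 2 h to 8 h in this assay as the read-out.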

Compound 4, half-life: > 3 h
Compound 4: only a limit was reported; the forecaster's own chance of this, stated with the estimate: 75%; the middle value is on the limit's open side.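

In this assay, for the compounds shown here, compound 4 gives > 3 h, a limit and not a number, so no step from compound 3 to compound 4 can be read. The compounds shown leave open any order among compound 1, compound 2, compound 3 and compound 4, and how far each half-life lies past the limit: the limit of > 3 h in this assay, at which 4 of the 4 values shown sit.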